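The source may report more compounds than this note shows. Statements on the series, on what has been measured and on what is new or still open speak of the compounds shown alone.

Compounds measured so far:
- compound 1, `CCCc1c(COc2ccc(C(=O)Cc3nnn[nH]3)cc2)ccc(C(C)=O)c1O`: 7.71
- compound 2, `CCCc1c(COc2ccc(C(=O)CCc3nnn[nH]3)cc2)ccc(C(C)=O)c1O`: 7.09
- compound 3, `CCCc1c(COc2ccc(C(=O)CC(C)(C)CC(=O)O)cc2)ccc(C(C)=O)c1O`: 7.73

These three share a core and differ only in the group on a saturated chain carbon bound to a carbonyl carbon. In a functional assay on ileum (Cavia porcellus) with cysteinyl leukotriene receptor (Homo sapiens) as the target (a lower number here means a less potent compound, a higher number a more potent compound, by a factor of ten per unit of this negative logarithm), compound 3 has the highest number of the three, but compound 1 sits within the scatter of it, so neither can be called more potent than the other; only compound 2 stands apart, as a number 0.64 log units higher from compound 2 to compound 3 (beyond the scatter) shows.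

Compound 4, `CCCc1c(COc2ccc(C(=O)CCCCCCc3nnn[nH]3)cc2)ccc(C(C)=O)c1O`, has not been measured. It differs from compound 3 in that (5-(1H-tetrazol-5-yl)pentyl in place of 1-(carboxymethyl)-1-methylethyl on a saturated chain carbon bound to a carbonyl carbon). Going by the values given here, two measured steps bear on this. Between compound 1 and compound 3 the swap of one acid-bearing group for the tetrazole itself gave a number 0.02 log units higher from compound 1 to compound 3 (within the scatter), no real change. Moving the tetrazole one carbon outward, however, gave a number 0.62 log units lower from compound 1 to compound 2 (beyond the scatter). Among the compounds with values here, compound 4 moves the tetrazole much further out, on a longer chain, a situation no measured compound covers, so the expectation carries wide uncertainty.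

The expected step is a number 0.53 log units lower from compound 3 to compound 4 (beyond the scatter), a modest loss in this assay. Compound 4 is therefore estimated at 7.2, with a range from 6.5 to 7.9.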

Compound 4, negative logarithm of the antagonist equilibrium constant: 7.33
The estimate for compound 4 lay 0.13 log units below the measured number, within the range that was stated.
By their numbers in this assay, from the lowest: compounds 2 and 4 (each within the scatter of the next); then compounds 1 and 3 (each within the scatter of the next).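

Carrying the tetrazole far out on the 5-(1H-tetrazol-5-yl)pentyl chain costs only a modest amount in this assay, with a number 0.40 log units lower from compound 3 to compound 4 (beyond the scatter) and a number 0.38 log units lower from compound 1 to compound 4 (beyond the scatter), so this position accepts a much longer group than the earlier compounds covered. The further comparison gives a number 0.24 log units higher from compound 2 to compound 4 (within the scatter), so these two compounds cannot be told apart, and the loss seen with the (1H-tetrazol-5-yl)methyl group does not deepen as the chain grows to this length. Nothing at hand offers a reason for this flat response to chain length.

From the compounds shown here alone, what happens at intermediate lengths stays open: a 3-(1H-tetrazol-5-yl)propyl group, for example, could fit the same level or depart from it, so the three tetrazole compounds do not fix the shape of the trend. A 5-carboxypentyl group would also be informative, since it would put a carboxylic acid on the same unbranched chain and so separate the effect of the acid group from that of the chain, which differ together between compound 3 and compound 4.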